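Methyl for Amino on the Sulfonyl of Compound 1

The source may report more compounds than this note shows. Statements on the series, on what has been measured and on what is new or still open speak of the compounds shown alone.

Measured so far:
compound 1 `NS(=O)(=O)c1ccc(-c2oc3ccccc3c(=O)c2-c2ccc(F)cc2)cc1` — 67%
compound 2 `CS(=O)(=O)c1ccc(-c2oc3ccccc3c(=S)c2-c2ccc(F)cc2)cc1` — < 5%

In an assay on isolated protein for inhibition of prostaglandin G/H synthase 1 (Mus musculus), tested at 10 ug/mL (on this read-out lower numbers stand for less inhibition and higher numbers for more inhibition at the one concentration tested (going by the name of the read-out)), compound 1 gives 67%, the only plain number shown here. Compound 2 sits at < 5%, which is a limit of the assay rather than a number (the limit of < 5% in this assay, at which 1 of the 2 values shown sits). Compound 3 `CS(=O)(=O)c1ccc(-c2oc3ccccc3c(=O)c2-c2ccc(F)cc2)cc1` has not been measured. It differs from compound 1 in one place (methyl in place of amino on a sulfonyl sulfur). Among the compounds with values here, no measured pair isolates this change, so the step is an expectation: a drop in this assay a number 32 percentage points lower from compound 1 to compound 3 (beyond the scatter) larger than the usual scatter. Compound 3 is expected to give 35%, between 5% and 65%.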

Compound 3, a percentage reported as inhibition, at one concentration (the size of the read-out at that concentration, not a potency): < 8%
Compound 3: a limit, no number; the forecaster's own chance of this, stated with the estimate: 20%; at least 27 percentage points between middle value and limit.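

In this assay, methyl in place of amino on a sulfonyl sulfur gives a number at least 59 percentage points lower from compound 1 to compound 3 (beyond the scatter). This single swap, from sulfamoyl to methylsulfonyl on an otherwise unchanged core, is therefore enough to change the result sharply at this position. The reading for compound 3 is a limit of the assay, not a number: the limit of < 8% in this assay, at which 1 of the 3 values shown sits.

How much inhibition compound 3 retains stays unknown, and the compounds shown do not explain the drop. Also open, on these data alone, is whether a methylamino group or a hydroxyl group on the same sulfur would behave like the amino or like the methyl.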